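A few compounds are considered here, and "the series" means these few. Any claim that something is new, unique, unknown or untested is made for them only; others in the source may bear on it.

Measured compounds:
- Compound 1 `CCCCCCCCCCCC[C@@H](O)[C@H]1CC[C@H]([C@H](O)CCCCCCCCCCNC(=O)c2cccs2)O1`: 3240 nM
- Compound 2 `CCCCCCCCCCCC[C@@H](O)[C@H]1CC[C@H]([C@H](O)CCCCCCCCCCNC(=O)c2ccco2)O1`: 100000 nM
- Compound 3 `CCCCCCCCCCCC[C@@H](O)[C@H]1CC[C@H]([C@H](O)CCCCCCCCCCNC(=O)c2ccoc2)O1`: 100000 nM

All three values come from a functional assay (RXF 631 cells, Homo sapiens) for inhibition, read by colorimetric assay and sulforhodamine B assay, with a stated time of 48 h; on this read-out higher numbers stand for weaker inhibition of growth and lower numbers for stronger inhibition of growth. Compound 3, at 100000 nM, is level with compound 2, and these two share the highest number of the set. The three compounds differ only in the ring on the amide carbonyl at the end of the chain.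

Compound 4 `CCCCCCCCCCCC[C@@H](O)[C@H]1CC[C@H]([C@H](O)CCCCCCCCCCNC(=O)c2cncs2)O1` keeps everything else and changes that ring: 1,3-thiazol-5-yl in place of furan-3-yl on a carbonyl carbon.

Going by the values given here, three measured steps bear on this change. Swapping one furan for the other did nothing visible: no change at the digits printed from compound 2 to compound 3 (within the scatter). Leaving the thiophen-2-yl ring for a furan mattered far more, both in a 31-fold higher number from compound 1 to compound 2 (1.49 log units; beyond the scatter) and in a 31-fold higher number from compound 1 to compound 3 (1.49 log units; beyond the scatter).

The entering ring holds sulfur, as the thiophen-2-yl ring of compound 1 does, so a move towards compound 1 (3240 nM) is expected, meaning a lower number than for compound 3. Among the compounds with values here, the entering ring also holds nitrogen, which none of the measured compounds has in this ring, so only part of that move is expected.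

The expected change is a 6.7-fold lower number from compound 3 to compound 4 (0.82 log units; beyond the scatter). The estimated value of compound 4 is 15000 nM, with an expected range from 3000 nM to 80000 nM.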

Compound 4, concentration for 50% growth inhibition: 100000 nM
The estimate for compound 4 lay 6.7-fold (0.82 log units) below the measured number; the whole stated range lies below it.
By their numbers in this assay, from the lowest: compound 1; then compounds 2, 3 and 4 (each within the scatter of the next).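

In this assay the 1,3-thiazol-5-yl ring gives no change at the digits printed from compound 3 to compound 4 (within the scatter) and also no change at the digits printed from compound 2 to compound 4 (within the scatter) and so groups with the two furan rings, while the comparison with the thiophen-2-yl ring gives a 31-fold higher number from compound 1 to compound 4 (1.49 log units; beyond the scatter) and leaves a clear gap. The opening compounds could not separate sulfur in the ring from the thiophen-2-yl ring as a whole, but compound 4 holds sulfur and still shares the high number of the furans, so sulfur alone does not bring the lower number of compound 1 at this position on the carbonyl carbon. No measurement here explains why the thiophen-2-yl ring stands apart from the other three rings.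

On these data alone, only compound 1 has the lower number, so it remains open whether the nitrogen of compound 4, the way its ring is joined to the carbonyl, or some other difference between the two rings accounts for the gap. A phenyl or pyridinyl ring on the same carbonyl carbon would show whether a six-membered ring can also reach the lower number, or whether the high number is the usual result here.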